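The source may report more compounds than this note shows. Statements on the series, on what has been measured and on what is new or still open speak of the compounds shown alone.

Measured so far in a functional assay on J774 cells (Mus musculus) for cytotoxicity; on this read-out higher numbers stand for weaker inhibition and lower numbers for stronger inhibition:
- compound 1 `CCCN(CCC)c1c([N+](=O)[O-])cc(S(=O)(=O)Nc2ccc(C)cc2)cc1[N+](=O)[O-]` gives 11000 nM
- compound 2 `CCCN(CCC)c1c([N+](=O)[O-])cc(S(=O)(=O)Nc2cccc(OC)c2)cc1[N+](=O)[O-]` gives 25000 nM
- compound 3 `CCCN(CCC)c1c([N+](=O)[O-])cc(S(=O)(=O)Nc2cccc(C)c2)cc1[N+](=O)[O-]` gives 16000 nM

Compound 3 sits within the scatter of both other compounds on these numbers, with a 1.5-fold higher number from compound 1 to compound 3 (0.16 log units; within the scatter) and a 1.6-fold lower number from compound 2 to compound 3 (0.19 log units; within the scatter) as the steps that reach it. Only compound 1 and compound 2 stand apart, with a 2.3-fold higher number from compound 1 to compound 2 (0.36 log units; beyond the scatter) as a modest step.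

Compound 4 `CCCN(CCC)c1c([N+](=O)[O-])cc(S(=O)(=O)Nc2cccc(Cl)c2)cc1[N+](=O)[O-]` differs from compound 3 in a single place, chloro in place of methyl on an aromatic carbon, meta to a large group (chloro in place of methyl on an aromatic carbon), which turns 3-methylphenyl into 3-chlorophenyl. Within the data shown here, no compound with chloro has been measured, so the evidence is indirect. Among the measured compounds shown here, the nearest precedent is compound 3 itself, reached by a swap on the same aromatic carbon in a 1.6-fold lower number from compound 2 to compound 3 (0.19 log units; within the scatter), and that step stayed within the scatter. Even the widest step among these compounds is modest, so no step beyond the scatter is expected in this assay for this change.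

The expected change is a 1.2-fold lower number from compound 3 to compound 4 (0.09 log units; within the scatter) and remains an estimate until tested. Compound 4 is estimated at 13000 nM, with an expected range from 6000 nM to 28000 nM for the measurement.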

Compound 4, half-maximal inhibitory concentration: 8700 nM
For compound 4 the middle estimate is 1.5-fold (0.17 log units) above the measured one; measured number inside the range.
By their numbers in this assay, from the lowest: compounds 4, 1, 3 and 2 (each within the scatter of the next, the first and the last beyond it).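

In this assay, among these compounds, chloro on this aromatic carbon gives the first step at this place that goes beyond the scatter, with a 2.9-fold lower number from compound 2 to compound 4 (0.46 log units; beyond the scatter) as a modest step, whereas the swap from methoxy to methyl stayed within it. Chloro itself cannot be told apart from methyl here (a 1.8-fold lower number from compound 3 to compound 4 (0.26 log units; within the scatter)), and 3-chlorophenyl cannot be told apart from the 4-methylphenyl of compound 1 (a 1.3-fold lower number from compound 1 to compound 4 (0.10 log units; within the scatter)), so the one separation this change adds lies between chloro and methoxy, and it remains modest. Nothing available explains why these groups compare as they do.

The compounds shown leave open whether a quite different group on this carbon, such as an amine, a carboxylic acid or a trifluoromethyl, would move the number further than any of these modest steps, or whether the range stays this narrow. They also leave open what chloro would do in the place where compound 1 carries its methyl, and whether the separation from methoxy would hold there.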